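The compounds below may be only part of what the source reports. "The series", "measured", "known", "first", "only" and "open" are said of these compounds alone.

Compound 1 `CCN(CC)c1ccc(NC(=O)c2cc(Cl)ccc2O)c(Cl)c1` is one of three compounds tested in an ADME assay on A549 cells (Homo sapiens) for cytotoxicity, read by resazurin assay, with a stated time of 48 h; on this read-out higher numbers stand for lower toxicity in this test and lower numbers for higher toxicity in this test. Compound 1 gives 55500 nM and stands second highest of the three numbers. Its nearest neighbour is compound 3 `O=C(Nc1ccc(NCc2ccncc2)cc1Cl)c1cc(Cl)ccc1O`, which gives 65300 nM in this assay; the furthest is compound 2 `O=C(Nc1ccc(NCc2cc(F)cc(C(F)(F)F)c2)cc1Cl)c1cc(Cl)ccc1O`, which gives 30900 nM in this assay. All three numbers lie within the scatter of one another, so none of the compounds can be called more or less toxic than another on this evidence.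

Compound 4 `O=C(Nc1ccc(NCc2ccc(O)nc2)cc1Cl)c1cc(Cl)ccc1O` has not yet been measured. It differs from compound 1 in one place: ((6-hydroxypyridin-3-yl)methyl)amino in place of diethylamino on an aromatic carbon. Within the data shown here, the only measured step that bears on this change is the one from compound 1 to compound 3, in which a ((pyridin-4-yl)methyl)amino group likewise replaced the diethylamino group on the same aromatic carbon; that step gave a 1.2-fold higher number from compound 1 to compound 3 (0.07 log units; within the scatter). Among the measured compounds shown here, the change to compound 4 is of the same kind, and no measured step suggests a movement beyond the scatter in this assay. Compound 4 is therefore expected to show a 1.1-fold higher number from compound 1 to compound 4 (0.03 log units; within the scatter), a step of no consequence. The estimate for compound 4 in this assay is 60000 nM, with a range from 30000 nM to 120000 nM.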

Compound 4, half-maximal cytotoxic concentration: 98500 nM
Beside the measured number, compound 4's estimate is 1.6-fold (0.22 log units) below it; low and high end bracket the measured number.
By their numbers in this assay, from the lowest: compounds 2, 1, 3 and 4 (each within the scatter of the next, the first and the last beyond it).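

In this assay, the aromatic carbon para to a large group carries the ((6-hydroxypyridin-3-yl)methyl)amino group in place of diethylamino with a 1.8-fold higher number from compound 1 to compound 4 (0.25 log units; within the scatter), so a second aromatic replacement for diethylamino at this position stays within the scatter, and it does so with 2 hydrogen-bond donors and 3 acceptors in the entering group. The ring on the saturated chain carbon can also be exchanged, 6-hydroxypyridin-3-yl in place of pyridin-4-yl, with a 1.5-fold higher number from compound 3 to compound 4 (0.18 log units; within the scatter), which shows that this read-out does not separate the two rings. No measured information is available that would explain these numbers.

On these data alone, what remains open is whether any group at this position would produce a step beyond the scatter, for example a morpholine, a longer alkyl chain or a carboxylic acid on the pyridine ring in place of the hydroxy group. The step from compound 3 to compound 4 also alters the ring attachment and the hydroxy group together, and a plain pyridin-3-yl group would be needed to read these two changes apart in this assay.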